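Branching the Chain: From Butyl to Isobutyl

A few compounds are considered here, and "the series" means these few. Any claim that something is new, unique, unknown or untested is made for them only; others in the source may bear on it.

Two sulfonamides that share one core have been measured in a functional assay on MCF7 cells (Homo sapiens) for antiproliferative activity, read by sulforhodamine B assay, with a stated time of 48 h; a lower number here means a stronger inhibitor, a higher number a weaker inhibitor. Compound 1 `CCCCc1ccc(NS(=O)(=O)c2ccc(N3CCNC3=O)cc2)cc1` gives 770 nM in this assay. Compound 2 `O=C1NCCN1c1ccc(S(=O)(=O)Nc2ccc3c(c2)CCC3)cc1` gives 240 nM in this assay. Of these two numbers, compound 1 has the higher one, so it is the weaker inhibitor of the pair, and its gap to compound 2 lies beyond the usual scatter.

Compound 3 `CC(C)Cc1ccc(NS(=O)(=O)c2ccc(N3CCNC3=O)cc2)cc1` has not yet been measured. It is built from the same atoms as compound 1, joined differently: isopropyl in place of propyl on a saturated chain carbon bound to an aromatic carbon. The shared core is untouched; cut one bond further out, the same difference reads as butyl to isobutyl. Going by the values given here, no pair of measured compounds shows what this rearrangement does here, so there is no step to lean on. The expectation for this assay is a modest step, in either direction, most likely none beyond the scatter. Compound 3 is therefore estimated at 900 nM (range 350 nM to 2500 nM), which means an expected step of a 1.2-fold higher number from compound 1 to compound 3 (0.07 log units; within the scatter).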

Compound 3, half-maximal inhibitory concentration: > 1000 nM
Compound 3 was reported as a limit; the forecaster's own chance of this, stated with the estimate: 3%; middle value at least 1.1-fold (0.04 log units) away from the limit.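

In this assay compound 3 gives > 1000 nM, and this is a limit of the assay, not a number. Moving one carbon of the butyl chain into a branch, with the same atoms and the shared core untouched, gives an at least 1.2-fold higher number from compound 1 to compound 3 (0.11 log units; that floor lies within the scatter), the first step read at this place, a saturated chain carbon bound to an aromatic carbon. This single pair offers no sign that the isobutyl chain lowers the number relative to the butyl chain, and the printed floor of the step cannot separate a small change from a large loss because the reading stops at a limit: the limit of > 1000 nM in this assay, at which 1 of the 3 values shown sits.

As far as these compounds go, how far the true value of compound 3 lies past that limit remains open, so the real size of this step could still be anywhere from within the scatter to well beyond it. Also open, from the compounds shown here alone, is what other groups would do in place of the butyl chain on the same core, such as a shorter ethyl chain, a longer hexyl chain, a more compact tert-butyl group, or a chain carrying an amine or a carboxylic acid.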